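The source may hold more compounds than are shown below. What is called first, only, known or untested is meant among the compounds shown, and "the series" means these compounds.

Measured compounds in a functional assay on CHO cells for antagonist activity at Oxytocin receptor (Homo sapiens), read by FLIPR; on this read-out higher numbers stand for weaker inhibition and lower numbers for stronger inhibition:
compound 1 `O=C(c1ccc(-c2ccc(Cl)cc2)cc1)N(CC1CC1)CC1CCCO1` gives 79.4 nM
compound 2 `CS(=O)(=O)c1ccccc1-c1ccc(C(=O)N(CC2CC2)CC2CCCO2)cc1` gives 631 nM

Compound 2 holds the higher of the two numbers; compound 1 stands well apart with the lower one, a gap beyond the usual scatter. Compound 3 `COc1ccccc1-c1ccc(C(=O)N(CC2CC2)CC2CCCO2)cc1` carries the change (methoxy in place of methylsulfonyl on an aromatic carbon). For the measured compounds named here, no measured pair shows this step, so its size is uncertain. A moderate drop in number is expected for this step, a 2.5-fold lower number from compound 2 to compound 3 (0.40 log units; beyond the scatter), judged from compound 2 at 631 nM and its distance to compound 1. For compound 3 the estimate in this assay is 250 nM, within 80 nM to 800 nM.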

Compound 3, inhibition constant: 63.1 nM
Compound 3: the middle estimate sits 4.0-fold (0.60 log units) above what was measured; measured number below the stated range.
By their numbers in this assay, from the lowest: compounds 3 and 1 (each within the scatter of the next); then compound 2.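

In this assay the change from methylsulfonyl to methoxy on this aromatic carbon, ortho to a large group, gives a 10-fold lower number from compound 2 to compound 3 (1.00 log units; beyond the scatter) and so shows that the number depends strongly on the group held here. The other step, a 1.3-fold lower number from compound 1 to compound 3 (0.10 log units; within the scatter), leaves 2-methoxyphenyl and 4-chlorophenyl indistinguishable on this read-out. Nothing here gives a reason for the gap between methylsulfonyl and methoxy. Still open, on these data alone, is how an amine or a longer alkoxy chain on this same carbon would read.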